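Removing the Aryl Methyl: Compound 2 to Compound 4

The compounds below may be only part of what the source reports. "The series", "measured", "known", "first", "only" and "open" are said of these compounds alone.

The series is built on a shared core, seen in compound 1 `Cc1nc(-c2ccccc2F)c(C(=O)N2CCN(c3cc(Cl)cc(Cl)c3)CC2)s1`, an aryl-substituted azole carrying an amide-linked piperazine that ends in a second aryl ring. In a functional assay on HL-60 cells (Homo sapiens) for inhibition, read by MTT assay, with a stated time of 72 h (a lower number here means a stronger inhibitor, a higher number a weaker inhibitor), compound 1 gives 157 nM. Compound 2 `Cc1ccc(N2CCN(C(=O)c3oc(C)nc3-c3ccccc3)CC2)cc1` carries the 4-methylphenyl ring on the piperazine; in this assay compound 2 reaches only > 1000 nM, which is a limit of the assay rather than a number. Compound 3 `Cc1ccc(C)c(N2CCN(C(=O)c3oc(C)nc3-c3ccc(Cl)cc3)CC2)c1` is reported in this assay as "not active" (no number reported), again without a number. Of the three values shown, compound 2 therefore stands at the weak end, at the limit of > 1000 nM in this assay, at which 1 of the 3 values shown sits. The step considered here leads to compound 4 `Cc1nc(-c2ccccc2)c(C(=O)N2CCN(c3ccccc3)CC2)o1`, which differs from compound 2 by hydrogen in place of methyl on an aromatic carbon. Among the compounds with values here, no pair of measured compounds isolates this change, so the size of its effect rests on expectation alone. The account expects the step that the limit leaves unreadable from compound 2 to compound 4 to stay within the scatter, and the estimate for compound 4 in this assay is 2000 nM, within a range from 500 nM to 8000 nM.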

Compound 4, half-maximal inhibitory concentration: 39.1 nM
Estimate against measurement, compound 4: 51-fold (1.71 log units) above; measured number outside the range, below it.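

In this assay, the change from 4-methylphenyl to phenyl gives an at least 25-fold lower number from compound 2 to compound 4 (1.40 log units; beyond the scatter), so this place, on an aromatic carbon para to a large group, responds strongly to a single methyl, and hydrogen there goes with the stronger inhibitor. The value of compound 2 is a limit and not a number, so the true size of the step cannot be read, only its lower bound: the limit of > 1000 nM in this assay, at which 1 of the 4 values shown sits.

As far as these compounds go, only methyl and hydrogen appear at this place, so it remains open whether any larger group would cost as much, or whether a methoxy or an amine there would behave like methyl. From the compounds shown here alone, whether the same change carries over to the cores of compound 1 and compound 3 also remains open.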